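Cyclopropyl in Place of Isopropyl and Cell Tolerance

This account rests on a few compounds, and the source may have more. Where it says the series, first, only, none or still open, it means among the compounds named here.

Compound 1 `CC(C)c1ccc2[nH]c(=O)c(CN(Cc3ccc(C(C)(C)C)cc3)C(C)c3ccc(N(C)C)c(Cl)c3)cc2c1` in a toxicity assay on MDCK cells (Canis lupus familiaris) for cytotoxicity, read by crystal violet staining, with a stated time of 48 h; a lower number here means that less compound is tolerated, a higher number that more compound is tolerated: > 10000 nM, a limit of the assay.
Compound 2 `COc1ccc([C@H](C)N(Cc2ccc(C(C)(C)C)cc2)Cc2cc3cc(C(C)C)ccc3[nH]c2=O)cc1` in this assay: > 10000 nM, likewise a limit.

Compound 2 stands at the limit of this assay, since (the limit of > 10000 nM in this assay, at which 2 of the 2 values shown sit). The step that the two limits leave unreadable from compound 1 to compound 2 therefore cannot be read. Compound 3 `COc1ccc([C@H](C)N(Cc2ccc(C(C)(C)C)cc2)Cc2cc3cc(C4CC4)ccc3[nH]c2=O)cc1` differs from compound 2 by cyclopropyl in place of isopropyl on an aromatic carbon. Among the compounds with values here, no measured step bears on this exchange; the one recorded step runs from one limit to another and gives no size. Compound 3 is therefore expected to remain at the limit of this assay, with the step that the limit leaves unreadable from compound 2 to compound 3 expected to lie within the scatter. The estimate for compound 3 is 15000 nM, ranging from 7000 nM to 50000 nM.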

Compound 3, half-maximal cytotoxic concentration: > 10000 nM
Compound 3 was reported as a limit; the forecaster's own chance of this, stated with the estimate: 85%; the middle value is on the limit's open side.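

Within the data shown here, no step from compound 2 to compound 3 can be read in this assay, since both compounds sit at a limit: the limit of > 10000 nM in this assay, at which 3 of the 3 values shown sit.
How much of any of these compounds the cells tolerate beyond that limit, and whether cyclopropyl in place of isopropyl alters it, remains open.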